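A few compounds are considered here, and "the series" means these few. Any claim that something is new, unique, unknown or untested is made for them only; others in the source may bear on it.

Series notes. Compound 1 `Clc1cc(Br)c2nnn(CC3CC3)c2c1` and compound 2 `Fc1cc(Br)c2nnn(CC3CC3)c2c1` share one core; compound 3 `Clc1cccc2c1nnn2CC1CC1` and the still unmeasured compound 4 `Fc1cccc2c1nnn2CC1CC1` share another. How the core of compound 1 and the core of compound 3 differ is not broken down here.

In a functional assay on cells for positive allosteric modulation of metabotropic glutamate receptor 2 (Homo sapiens), read by fluorescence and calcium flux, with a stated time of 30 min (a lower number here means that less compound is needed, a higher number that more compound is needed for the effect), compound 1 gives 60 nM, and compound 2 gives 70 nM in this assay. The change between these two is fluoro in place of chloro on an aromatic carbon, and the step it made is a 1.2-fold higher number from compound 1 to compound 2 (0.07 log units; within the scatter). In this assay compound 3 gives 90 nM; its number and that of compound 2 lie within the scatter of each other, and so do its number and that of compound 1.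

Compound 4 differs from compound 3 by fluoro in place of chloro on an aromatic carbon. Among the compounds with values here, this is the same kind of change as the one between compound 1 and compound 2, not the same change: in the earlier pair the place is meta to a bromo group, meta to a fused ring and para to a fused ring, whereas here it is ortho to a fused ring and meta to a fused ring. Within the data shown here, only one earlier instance exists, so the expectation rests on compound 1 and compound 2 alone. For compound 4 the step is expected to be a 1.2-fold higher number from compound 3 to compound 4 (0.07 log units; within the scatter) in this assay, set beside the earlier one, because a 1.2-fold higher number from compound 1 to compound 2 (0.07 log units; within the scatter) stayed within the scatter. Compound 4 is therefore estimated at 105 nM in this assay, with a range from 55 nM to 200 nM.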

Compound 4, half-maximal effective concentration: 1070 nM
Compound 4: middle estimate off by 10-fold (1.01 log units), on the low side, outside the stated range (above it).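

On the core of compound 3, fluoro in place of chloro on an aromatic carbon gives a 12-fold higher number from compound 3 to compound 4 (1.08 log units; beyond the scatter) in this assay, so on this core the exchange cannot be treated as neutral. The effect of this change did not carry from one core to the other, and a step read on one of these cores is no safe guide to the same change on the other, as the two steps show: the same change on two cores in this assay, a 1.2-fold higher number (0.07 log units; within the scatter) from compound 1 to compound 2 and a 12-fold higher number (1.08 log units; beyond the scatter) from compound 3 to compound 4, 10-fold (1.01 log units) apart, beyond the scatter of two such steps

What this does not show is the reason for the gap: with a single pair on each core, a difference between the cores cannot be separated from a difference in the surroundings of the place changed, and two pairs give no rule for any further core in the series.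

Still open is whether the gap goes with the bromo group carried by compound 1 and compound 2, since no pair shown changes that group alone. Also open, on these data alone, is how other groups on this aromatic carbon, such as methyl, methoxy, nitrile or an amine, would behave on either core in this assay, and whether any of them would follow chloro or fluoro.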